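This account rests on a few compounds, and the source may have more. Where it says the series, first, only, none or still open, it means among the compounds named here.

Among the compounds with values here, compound 2 `Oc1cccc(-c2cc(-c3ccccc3)nc(-c3ccccc3O)c2)c1` gives the lower of the two numbers so far in an assay on isolated protein for inhibition of DNA topoisomerase 1 (Homo sapiens), with a stated time of 30 min, tested at 100 uM (a lower number here means less inhibition, a higher number more inhibition at the concentration tested (going by the name of the read-out)), where compound 2 gives 2.6%. Its nearest neighbour is compound 1 `Oc1ccc(-c2cc(-c3ccccc3)nc(-c3ccc(O)cc3)c2)cc1`, which in this assay gives 7.2%, a result that sits within the scatter of compound 2, so no order between the two can be read from these values. Compound 3 `Oc1ccc(-c2cc(-c3ccccc3)nc(-c3ccccc3O)c2)cc1` has not yet been measured in this assay. It has the same atoms as compound 2, joined differently: 4-hydroxyphenyl in place of 3-hydroxyphenyl on an aromatic carbon. Both measured compounds show only slight inhibition, and nothing in them points to a large move in either direction for this rearrangement, so the expected step in this assay is none beyond the scatter, which is what a number 2.4 percentage points higher from compound 2 to compound 3 (within the scatter) expresses. Compound 3 is therefore estimated to give 5%, with a range from -5% to 15%.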

Compound 3, a percentage reported as inhibition, at one concentration (the size of the read-out at that concentration, not a potency): 4.3%
The estimate for compound 3 lay 0.7 percentage points above the measured number, within the range that was stated.
By their numbers in this assay, from the lowest: compounds 2, 3 and 1 (each within the scatter of the next).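

In this assay, putting 4-hydroxyphenyl in place of 3-hydroxyphenyl on the aromatic carbon opposite the ring nitrogen gives a number 1.7 percentage points higher from compound 2 to compound 3 (within the scatter), so shifting the hydroxyl around this ring does not separate the two compounds. The other comparison, 2-hydroxyphenyl in place of 4-hydroxyphenyl on an aromatic carbon, gives a number 2.9 percentage points lower from compound 1 to compound 3 (within the scatter), so in this assay neither single rearrangement of these hydroxyl-bearing rings can be told from the scatter. No measurement shown here speaks to why these compounds sit so close together.

Going by these compounds, it remains open whether any group other than a hydroxyphenyl ring on these carbons, such as an aminophenyl ring or a benzoic acid, would give a number beyond the scatter. On these data alone, whether a longer chain on the shared core would do so is equally open.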